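The compounds below may be only part of what the source reports. "The series", "measured", "known", "first", "only" and "open" are said of these compounds alone.

Three compounds have been measured in an assay for displacement of a labelled ligand from protein deacetylase HDAC6 (Homo sapiens), read by fluorescence polarization, with a stated time of 10 min; on this read-out lower numbers stand for stronger inhibition and higher numbers for weaker inhibition:

Compound 1 `Cc1n[nH]c(=O)nc1Nc1ccc(C(C)C)cc1`: "not active" (no number reported)
Compound 2 `O=C(O)CCc1nc2cc(Cl)ccc2s1`: 55000 nM
Compound 3 `O=C(O)CCc1nc2ccccc2nc1OCc1cccs1`: "not active" (no number reported)

Of these three, only compound 2 has a number at all, and in this assay compound 2 gives 55000 nM, a result that on this read-out stands for weak inhibition. Compound 3 belongs to the other group: for compound 3 the assay reports no number, only the statement that it was not active, and compound 1 stands in the same position. So compound 3 cannot be placed against compound 2 on a scale; it can only be said that compound 2 produced a measurable result and compound 3 did not.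

The next compound, compound 4 `O=C(O)CCc1nc2ccccc2nc1OCc1ccccc1`, keeps the core and the acid-bearing chain of compound 3 and changes one part: phenyl in place of thiophen-2-yl on a saturated chain carbon bound to an oxygen on an aromatic ring. Going by the values given here, no measured pair shows what such a swap does here, so no step size can be read off. Given that compound 3 reached no number in this assay, the change from thiophen-2-yl to phenyl is not expected to lift compound 4 far beyond the scatter of what was seen; the most likely outcome for compound 4 is again weak or no measurable inhibition. Compound 4 is therefore estimated at 80000 nM, within a range of 20000 nM to 300000 nM.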

Compound 4, half-maximal inhibitory concentration: "not active" (no number reported)
Compound 4: no number reported; the estimate stays without a comparison.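

In this assay compound 3 and compound 4 both come without a number, so no step can be read for the change from (thiophen-2-yl)methyl to benzyl. No measurement shown here offers an explanation for this result. The compounds shown leave open whether thiophen-2-yl and phenyl differ at all in this assay.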